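The source may hold more compounds than are shown below. What is called first, only, known or untested is meant among the compounds shown, and "the series" means these compounds.

Working notes on the series. Of the compounds shown here, three have been measured. Compound 1 `Fc1ccc(C2=CC3CNCC(C2)C3)cn1` gives 0.4 nM in an in vitro assay on SH-EP1 cells for displacement of a labelled ligand from Neuronal acetylcholine receptor; alpha4/beta2 (Homo sapiens); a higher number here means a weaker inhibitor, a lower number a stronger inhibitor. Compound 3 `Clc1cncc(C2=CC3CNCC(C2)C3)c1` gives 0.4 nM in this assay. Compound 2 `Fc1ccc(Oc2cncc(C3=CC4CNCC(C3)C4)c2)cc1` gives 0.6 nM in this assay; this is the highest of the three numbers, but its distance to compound 1 and to compound 3 is within the scatter, so the three cannot be ordered on these numbers.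

Compound 4 `COc1ccc(Oc2cncc(C3=CC4CNCC(C3)C4)c2)cc1` has not been measured. It differs from compound 2 in one place: methoxy in place of fluoro on an aromatic carbon. Within the data shown here, no measured pair shows this change, so its size is not set by any measured step. Since compound 2 gives 0.6 nM and the change is confined to one substituent on the six-membered aromatic ring of carbon only, the step is expected to be small, in either direction, or none beyond the scatter. The expected step is a 1.7-fold higher number from compound 2 to compound 4 (0.22 log units; within the scatter). For compound 4 the estimate in this assay is 1 nM, with a range from 0.3 nM to 3 nM.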

Compound 4, inhibition constant: 1.4 nM
Compound 4: the middle estimate sits 1.4-fold (0.15 log units) below what was measured; measured number inside the range.
By their numbers in this assay, from the lowest: compounds 1, 3 and 2 (each within the scatter of the next); then compound 4.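

The 4-fluorophenyl to 4-methoxyphenyl change gives the first step the series can read: in this assay it is a 2.3-fold higher number from compound 2 to compound 4 (0.37 log units; beyond the scatter), so the substituent at this place, para to a large group, does register in the number. The step is modest, and methoxy, with its two heavy atoms and one hydrogen-bond acceptor, is accommodated here with only that rise. No data shown bear on the cause of this step.

A single step cannot separate the contribution of the oxygen from that of the added carbon; a hydroxy group, an amine, a chlorine or a longer chain such as ethoxy at the same place would bear on this. Also open, as far as these compounds go, is whether fluoro itself differs from hydrogen here, and whether the step would keep its size on another core.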